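Trimming the Amide Group on a Shared Core

The source may report more compounds than this note shows. Statements on the series, on what has been measured and on what is new or still open speak of the compounds shown alone.

Compound 3 `COc1ccc(-c2cn3cc(C4=CCN(C(=O)c5ccccc5)CC4)ccc3n2)cc1OC` holds the second highest of the three numbers measured in a functional assay on HeLa cells (Homo sapiens) for antiproliferative activity, read by MTT assay, with a stated time of 48 h (a lower number here means a stronger inhibitor, a higher number a weaker inhibitor), where compound 3 gives 10200 nM. The other two are compound 2 `COc1ccc(-c2cn3cc(C4=CCN(S(=O)(=O)CCc5ccccc5)CC4)ccc3n2)cc1OC`, which gives 8980 nM, and compound 1 `COc1ccc(-c2cn3cc(C4=CCN(S(=O)(=O)c5ccccc5)CC4)ccc3n2)cc1OC`, which gives 12600 nM; the steps of a 1.4-fold lower number from compound 1 to compound 2 (0.15 log units; within the scatter), a 1.2-fold lower number from compound 1 to compound 3 (0.09 log units; within the scatter) and a 1.1-fold higher number from compound 2 to compound 3 (0.06 log units; within the scatter) all stay within the scatter. Compound 4 `COc1ccc(-c2cn3cc(C4=CCN(C(=O)C5CC5)CC4)ccc3n2)cc1OC` differs from compound 3 by cyclopropyl in place of phenyl on a carbonyl carbon. Among the measured compounds shown here, no measured step exchanges phenyl for cyclopropyl; the three measured steps, each within the scatter, show only that swaps on the amine nitrogen in a ring have left the numbers in this assay unmoved. A step of no size beyond the scatter is therefore expected, a 1.1-fold higher number from compound 3 to compound 4 (0.03 log units; within the scatter). Compound 4 is estimated at 11000 nM, with a range from 5000 nM to 25000 nM.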

Compound 4, half-maximal inhibitory concentration: 15800 nM
Compound 4: the middle estimate sits 1.4-fold (0.16 log units) below what was measured; measured number inside the range.
By their numbers in this assay, from the lowest: compounds 2, 3, 1 and 4 (each within the scatter of the next).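

In this assay, cyclopropyl in place of phenyl on a carbonyl carbon gives a 1.5-fold higher number from compound 3 to compound 4 (0.19 log units; within the scatter), so a six-membered aromatic ring and a three-membered non-aromatic ring are not told apart at this place. The wider swaps on the amine nitrogen in a ring, a 1.8-fold higher number from compound 2 to compound 4 (0.25 log units; within the scatter) and a 1.3-fold higher number from compound 1 to compound 4 (0.10 log units; within the scatter), also stay within the scatter, so all four compounds remain within the scatter of one another. Nothing measured here speaks to the reason for this. Going by these compounds, it remains open whether an amine, a carboxylic acid or a longer chain on that carbonyl carbon would move the number beyond the scatter.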